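This account rests on a few compounds, and the source may have more. Where it says the series, first, only, none or still open, it means among the compounds named here.

Measured so far in an ADME assay on NCI-H460 cells (Homo sapiens) for cytotoxicity, read by MTT assay, with a stated time of 72 h; a higher number here means a weaker inhibitor, a lower number a stronger inhibitor:
Compound 1 `COc1cccc(-n2nnc(-c3ccccc3NC(=O)c3ccc(N)cc3)n2)c1`: > 100000 nM, a limit of the assay.
Compound 2 `COc1cccc(-n2nnc(-c3ccccc3NC(=O)c3ccc(NC(C)=O)cc3)n2)c1`: > 100000 nM, a limit of the assay.
Compound 3 `COc1cccc(-n2nnc(-c3ccccc3NC(=O)c3ccc(N=[N+]=[N-])cc3)n2)c1`: 20300 nM.

Compound 3 alone gives a number, and beside it stands (the limit of > 100000 nM in this assay, at which 2 of the 3 values shown sit). Compound 4 `COc1cccc(-n2nnc(-c3ccccc3NC(=O)c3ccc(NC(=O)CBr)cc3)n2)c1` changes the same place: ((bromomethyl)carbonyl)amino in place of azido on an aromatic carbon, with ((bromomethyl)carbonyl)amino in place of azido on an aromatic carbon. Going by the values given here, two measured steps bear on this place: an at least 4.9-fold lower number from compound 1 to compound 3 (0.69 log units; beyond the scatter) and an at least 4.9-fold lower number from compound 2 to compound 3 (0.69 log units; beyond the scatter). Both end at azido, so neither fixes the size of this change, and the entering group shares its amide with the acetamido of compound 2. A modest rise in the number is therefore expected, though it is uncertain in size. The expected step is a 1.5-fold higher number from compound 3 to compound 4 (0.17 log units; within the scatter). For compound 4 the estimated value is 30000 nM, within an expected range of 4000 nM to 100000 nM.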

Compound 4, half-maximal inhibitory concentration: > 100000 nM
Compound 4: no number, only a limit; the forecaster's own chance of this, stated with the estimate: 25%; middle value at least 3.3-fold (0.52 log units) away from the limit.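

In this assay, ((bromomethyl)carbonyl)amino in place of azido on the aromatic carbon gives an at least 4.9-fold higher number from compound 3 to compound 4 (0.69 log units; beyond the scatter), so azido remains the only group shown at this position with a readable number. Compound 4 gives only a limit of the assay, not a number, and that limit now holds most of the series: the limit of > 100000 nM in this assay, at which 3 of the 4 values shown sit. The steps from compound 1 and compound 2 to compound 4 cannot be read.

From the compounds shown here alone, how amino, acetamido and ((bromomethyl)carbonyl)amino rank among themselves stays open. So does whether a carboxylic acid or a longer chain at this position would give a number.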